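Hydrogen in place of trifluoromethyl on compound 2

This account rests on a few compounds, and the source may have more. Where it says the series, first, only, none or still open, it means among the compounds named here.

Measured in a functional assay on HT-29 cells (Homo sapiens) for inhibition, read by sulforhodamine B assay, with a stated time of 48 h; on this read-out higher numbers stand for weaker inhibition of growth and lower numbers for stronger inhibition of growth:
Compound 1 `O=C(Nc1cccc(-n2cc(-c3ccncc3)c(-c3ccc(Cl)c(O)c3)n2)c1)Nc1cccc(C(F)(F)F)c1`: > 32500 nM
Compound 2 `COc1cc(-c2nn(-c3cccc(NC(=O)c4cccc(C(F)(F)F)c4)c3)cc2-c2ccncc2)ccc1Cl`: 20100 nM

The entry for compound 1 is a limit of the assay and not a number: > 32500 nM. For the measured compounds named here, that leaves compound 2, at 20100 nM, as the only compound with an actual number in this assay, so it cannot yet be placed within a series of measured values.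

The next compound, compound 3 `COc1cc(-c2nn(-c3cccc(NC(=O)c4ccccc4)c3)cc2-c2ccncc2)ccc1Cl`, keeps the rest of compound 2 and differs from it in one place: hydrogen in place of trifluoromethyl on an aromatic carbon. Hydrogen stands in place of trifluoromethyl on an aromatic carbon, meta to a large group, which turns 3-(trifluoromethyl)phenyl into phenyl.

Going by the values given here, no measured pair of compounds shows this change, so the expectation starts from compound 2 at 20100 nM and stays cautious. The expected move in this assay leans slightly toward weaker inhibition of growth but remains within the usual scatter, and a result reported only as a limit would be no surprise. The estimated step is a 1.3-fold higher number from compound 2 to compound 3 (0.11 log units; within the scatter). For compound 3 the estimated value is 26000 nM, with an expected range of 11000 nM to 45000 nM.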

Compound 3, concentration for total growth inhibition: > 100000 nM
Compound 3 was reported as a limit (the forecaster's own chance of this, stated with the estimate: 40%); middle value at least 3.8-fold (0.58 log units) away from the limit.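

In this assay, hydrogen in place of trifluoromethyl, which turns 3-(trifluoromethyl)phenyl into phenyl, gives an at least 4.9-fold higher number from compound 2 to compound 3 (0.69 log units; beyond the scatter), the first step read at this position, and it lies beyond the usual scatter. For the compounds shown here, the size of this step is only a lower bound, because the entry for compound 3 is a limit of the assay and not a number: the limit of > 100000 nM in this assay, at which 1 of the 3 values shown sits. With the rest of the structure unchanged, this pair therefore shows that inhibition of growth weakens when trifluoromethyl gives way to hydrogen on this aromatic carbon, something the earlier compounds could not show, as they differ from each other in more than one place.

As far as these compounds go, how far the inhibition of growth falls with this change remains open, since only a limit marks its end point, and one pair cannot show whether the same step would hold on another core. Also open, from the compounds shown here alone, is whether a methyl group, a chlorine atom or a methoxy group on the same carbon would stay close to compound 2 or fall away as hydrogen does.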